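Extending the para-alkyl chain on the amide aryl ring

This account rests on a few compounds, and the source may have more. Where it says the series, first, only, none or still open, it means among the compounds named here.

Measured compounds:
- Compound 1 `O=C(Nc1cccc(-c2oc3cc(-c4ccc(F)cc4)ccc3c(=O)c2O)c1)c1ccc(F)cc1`: 14600 nM
- Compound 2 `O=C(Nc1cccc(-c2oc3cc(-c4ccc(F)cc4)ccc3c(=O)c2O)c1)c1ccc(C(F)(F)F)cc1`: 33000 nM
- Compound 3 `CCc1ccc(C(=O)Nc2cccc(-c3oc4cc(-c5ccc(F)cc5)ccc4c(=O)c3O)c2)cc1`: 24600 nM

All three compounds share one core and differ only in the group carried by the benzamide ring. In a functional assay on GTL 16 cells for antiproliferative activity against GTL 16 cell line (Homo sapiens), read by CCK-8 assay, with a stated time of 72 h (a higher number here means a weaker inhibitor, a lower number a stronger inhibitor), compound 3 sits second highest of the three numbers, but its neighbours are close: a 1.3-fold lower number from compound 2 to compound 3 (0.13 log units; within the scatter) and a 1.7-fold higher number from compound 1 to compound 3 (0.23 log units; within the scatter), so no order among the three can be read. Going by the values given here, the one step that passes the scatter is a 2.3-fold higher number from compound 1 to compound 2 (0.35 log units; beyond the scatter), and even that is modest.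

Compound 4 `CCCc1ccc(C(=O)Nc2cccc(-c3oc4cc(-c5ccc(F)cc5)ccc4c(=O)c3O)c2)cc1` continues from compound 3 by methyl in place of hydrogen on a saturated chain carbon, two bonds along the chain from an aromatic carbon. Among the compounds with values here, none of the measured steps adds to a chain; they all swap one group for another at the same position. The two steps that reach compound 3, from compound 1 and from compound 2, both stay within the scatter, which gives no hint that a single carbon added here will move the number far. The expectation for compound 4 is therefore a step of about a 1.0-fold higher number from compound 3 to compound 4 (0.01 log units; within the scatter), that is, nothing beyond the scatter. The estimate for compound 4 in this assay is 25000 nM, with a range from 10000 nM to 60000 nM.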

Compound 4, half-maximal inhibitory concentration: 20400 nM
The estimate for compound 4 lay 1.2-fold (0.09 log units) above the measured number; low and high end bracket the measured number.
By their numbers in this assay, from the lowest: compounds 1, 4, 3 and 2 (each within the scatter of the next, the first and the last beyond it).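

Lengthening the chain from ethyl to propyl is the first change here that extends a group rather than swapping it for another, and in this assay it gives a 1.2-fold lower number from compound 3 to compound 4 (0.08 log units; within the scatter) and so stays within what repeated measurements alone could produce. Propyl also cannot be separated from the other two groups, with a 1.6-fold lower number from compound 2 to compound 4 (0.21 log units; within the scatter) and a 1.4-fold higher number from compound 1 to compound 4 (0.15 log units; within the scatter) both within the scatter, even though the fluoro and trifluoromethyl compounds differ from each other beyond it; compound 4 therefore fits between two compounds that can be told apart without establishing any order of its own, and ethyl and propyl alone define no trend with chain length. No measurement available here accounts for these numbers.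

Going by these compounds, it remains open whether a longer chain such as butyl or hexyl, a branched one such as isopropyl, or a quite different group such as an amine or a carboxylic acid would shift the number further at this position. All four compounds also keep the shared core, so they cannot show whether changes there would matter more than changes on the benzamide ring.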